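Aryl Ether to Isobutyl on a Quinoline-Type Core

This account rests on a few compounds, and the source may have more. Where it says the series, first, only, none or still open, it means among the compounds named here.

Of the compounds shown here, three have been measured in an ADME assay for permeability, using PAMPA, with a stated time of 30 min, at pH 7.4; a higher number here means that the compound crosses the layer faster, a lower number that the compound crosses the layer more slowly. Compound 1 `COc1ccc(Oc2ccc3c(NCCCNCc4cc(F)ccc4OC)ccnc3c2)cc1` gives 317 10^-6 cm/s. Compound 2 `Fc1ccc(-c2ccc3c(NCCCNCc4ccco4)ccnc3c2)cc1` gives 237 10^-6 cm/s, a number within the scatter of compound 1, so the two cannot be told apart. Compound 3 `CC(C)CCc1ccc2c(NCCCNCc3ccco3)ccnc2c1` gives 23 10^-6 cm/s, well below both. Compound 4 `COc1ccc(F)cc1CNCCCNc1ccnc2cc(CC(C)C)ccc12` differs from compound 1 in one place: isobutyl in place of 4-methoxyphenoxy on an aromatic carbon. Within the data shown here, one measured step bears on this change and it was large: a 10-fold lower number from compound 2 to compound 3 (1.01 log units; beyond the scatter). A drop of similar size is therefore expected in this assay: a 9.9-fold lower number from compound 1 to compound 4 (1.00 log units; beyond the scatter). Compound 4 is estimated to give 32 10^-6 cm/s, with a plausible range from 10 10^-6 cm/s to 100 10^-6 cm/s.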

Compound 4, apparent permeability: 23 10^-6 cm/s
For compound 4 the middle estimate is 1.4-fold (0.14 log units) above the measured one, and the stated range covers the measured number.
By their numbers in this assay, from the lowest: compounds 3 and 4 (each within the scatter of the next); then compounds 2 and 1 (each within the scatter of the next).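

In this assay, replacing 4-methoxyphenoxy with isobutyl gives a 14-fold lower number from compound 1 to compound 4 (1.14 log units; beyond the scatter). This is the second large drop at this aromatic carbon, and it appears with a different departing group and a different amine side chain from the earlier pair. Across these two pairs, a group carrying a six-membered aromatic ring gives way to a branched carbon chain with no ring, and the number falls each time. Nothing measured here explains the drop. Going by these compounds, whether an amine or a carboxylic acid at this carbon would give a similar fall remains open.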